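The source may report more compounds than this note shows. Statements on the series, on what has been measured and on what is new or still open speak of the compounds shown alone.

Measured in a physicochemical assay for solubility, read by HPLC, with a stated time of 24 h; on this read-out higher numbers stand for higher solubility and lower numbers for lower solubility:
- compound 1 `CC(C)(C)c1[nH]cnc1/C=c1\[nH]c(=O)/c(=C/c2cccc(C(=O)c3ccccc3)c2)[nH]c1=O`: < 0.1 ug/mL
- compound 2 `CC(C)(C)c1[nH]cnc1/C=c1\[nH]c(=O)/c(=C/c2cccc(C(=O)N3CCC3)c2)[nH]c1=O`: 4.23 ug/mL

Compound 1 stands at < 0.1 ug/mL, which is a limit of the assay and not a number. The position on the data in hand is this: the limit of < 0.1 ug/mL in this assay, at which 1 of the 2 values shown sits.

Compound 3 `CC(C)(C)c1[nH]cnc1/C=c1\[nH]c(=O)/c(=C/c2cccc(C(=O)N3CCCC3)c2)[nH]c1=O` has not yet been measured. It keeps the shared core of compound 1 and carries pyrrolidin-1-yl in place of phenyl on a carbonyl carbon.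

For the measured compounds named here, one measured step bears on this change, with azetidin-1-yl in place of phenyl on the same kind of carbonyl carbon: an at least 42-fold higher number from compound 1 to compound 2 (1.62 log units; beyond the scatter). That step is large and beyond the scatter. Going by the values given here, it is also the only such step, so the expectation rests on a single pair.

In this assay, among the compounds with values here, a large step towards the higher number is therefore expected, of a size similar to the one that took compound 2 to 4.23 ug/mL. The expected step is an at least 30-fold higher number from compound 1 to compound 3 (1.47 log units; beyond the scatter).

For compound 3 the estimated value is 3 ug/mL.

The expected range for compound 3 runs from 0.7 ug/mL to 12 ug/mL.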

Compound 3, solubility: 0.454 ug/mL
For compound 3 the middle estimate is 6.6-fold (0.82 log units) above the measured one; measured number below the stated range.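

In this assay, pyrrolidin-1-yl on the carbonyl carbon also gives a gain over phenyl, an at least 4.5-fold higher number from compound 1 to compound 3 (0.65 log units; beyond the scatter), so the rise is no longer tied to azetidin-1-yl alone. The two rings are not interchangeable at this position: the change between them gives a 9.3-fold lower number from compound 2 to compound 3 (0.97 log units; beyond the scatter), a gap beyond the scatter, so the identity of the group entering on the carbonyl carbon matters as well as the loss of phenyl. Compound 1 stands at a limit of the assay and not at a number, so the steps from it give only a floor and not a true size: the limit of < 0.1 ug/mL in this assay, at which 1 of the 3 values shown sits.

Going by these compounds, with only these two rings in hand, no rule for ring size can be drawn, and it remains open where piperidin-1-yl, morpholin-4-yl or an open-chain dimethylamino group on the same carbonyl carbon would fall. Also open, on these data alone, is whether an amine or a carboxylic acid carried on such a ring would take the series past compound 2, which gives 4.23 ug/mL in this assay.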